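Swapping a Methyl for a Methylsulfonyl on Compound 1

The source may hold more compounds than are shown below. What is called first, only, known or untested is meant among the compounds shown, and "the series" means these compounds.

Of the compounds shown here, three built on one shared core have been measured in a functional assay on KB cells (Homo sapiens) for cytotoxicity; a lower number here means a stronger inhibitor, a higher number a weaker inhibitor. Compound 1 `COc1ccc2c(c1)C(=O)C=CC2=O` gives 33900 nM in this assay, the highest of the three numbers. Compound 2 `O=C1C=CC(=O)c2c(Oc3ccco3)cccc21` gives 13400 nM, and compound 3 `O=C1C=CC(=O)c2c(Oc3cccs3)cccc21` gives 6230 nM. Compound 1 stands nearest to compound 2 and furthest from compound 3, and both gaps lie beyond the usual scatter, so compound 1 is the weakest inhibitor of the three. Going by the values given here, the single step measured between compounds differing in one place, a 2.2-fold lower number from compound 2 to compound 3 (0.33 log units; beyond the scatter), concerns a thiophen-2-yl in place of furan-2-yl on an oxygen on an aromatic ring.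

Compound 4 `CS(=O)(=O)Oc1ccc2c(c1)C(=O)C=CC2=O` differs from compound 1 in this way: methylsulfonyl in place of methyl on an oxygen on an aromatic ring. Among the compounds with values here, that change also sits on an oxygen on an aromatic ring, so the step from compound 2 to compound 3 is the only one that bears on it; it was modest, but it exchanged one ring for another rather than methyl for methylsulfonyl, and no measured step shows the present exchange. Compound 4 is therefore expected to show a step of a 1.7-fold lower number from compound 1 to compound 4 (0.23 log units; within the scatter), likely within or only just beyond the scatter. The estimate for compound 4 in this assay is 20000 nM, ranging from 6000 nM to 60000 nM.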

Compound 4, half-maximal inhibitory concentration: 11600 nM
The estimate for compound 4 lay 1.7-fold (0.24 log units) above the measured number, within the range that was stated.
By their numbers in this assay, from the lowest: compounds 3, 4 and 2 (each within the scatter of the next, the first and the last beyond it); then compound 1.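

In this assay, going by these compounds alone, the exchange of methyl for methylsulfonyl on an oxygen on an aromatic ring gives a 2.9-fold lower number from compound 1 to compound 4 (0.47 log units; beyond the scatter), and this is the first measured step for this exchange rather than for one ring in place of another. It shows that this oxygen of compound 1 can carry a group of four heavy atoms, with two hydrogen-bond acceptors, in place of a single carbon without the number rising; the number instead falls modestly, by more than the scatter. Nothing measured here explains why the number falls with this exchange.

The compounds shown leave open whether the sulfonyl part matters or whether other groups on this oxygen would give the same step, which an acetyl, a free hydroxyl or a longer chain such as propylsulfonyl could separate. They also leave open whether methylsulfonyl would give a step of like size in place of the furan-2-yl of compound 2 or the thiophen-2-yl of compound 3.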